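Chloro in place of ethynyl on a thiourea-linked sulfonamide

The source may report more compounds than this note shows. Statements on the series, on what has been measured and on what is new or still open speak of the compounds shown alone.

In a functional assay on A549 cells (Homo sapiens) for antiproliferative activity, read by MTT assay, with a stated time of 72 h (a higher number here means a weaker inhibitor, a lower number a stronger inhibitor), compound 3 `C#Cc1cccc(Nc2ncnc3ccc(NC(=S)Nc4ccc(S(N)(=O)=O)cc4)cc23)c1` gives only a limit, > 40000 nM, and so stands at the limit of > 40000 nM in this assay, at which 2 of the 3 values shown sit, rather than at a number. Compound 4 `NS(=O)(=O)c1ccc(NC(=S)Nc2ccc3ncnc(Nc4cccc(Cl)c4)c3c2)cc1` differs from it by chloro in place of ethynyl on an aromatic carbon. The other measured compounds carry a different core: compound 1 `COc1cc2ncnc(Nc3ccc(F)c(Cl)c3)c2cc1OCCCCC(=O)Nc1ccc(S(N)(=O)=O)cc1` gives 15500 nM in this assay. Compound 2 `COc1cc2ncnc(Nc3cc(F)c(F)c(F)c3)c2cc1OCCCCC(=O)Nc1ccc(S(N)(=O)=O)cc1` gives a limit, > 40000 nM. Within the data shown here, the only measured step, an at least 2.5-fold higher number from compound 1 to compound 2 (0.41 log units; beyond the scatter), changes the aryl group on the nitrogen of that other core and does not touch the ethynyl that compound 4 replaces, so it bears only loosely on this change. Compound 4 is therefore expected to stay near the limit, a number no higher from compound 3 to compound 4 (the limit leaves the size open). Compound 4 is estimated at 40000 nM, within 12000 nM to 80000 nM.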

Compound 4, half-maximal inhibitory concentration: > 40000 nM
Compound 4 ended at the assay's limit; the forecaster's own chance of this, stated with the estimate: 60%; the middle value sits exactly at the limit.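

Compound 3 and compound 4 both end at a limit of this assay, so no step can be read between them. The compounds shown leave open whether ethynyl or chloro gives the stronger inhibitor on this thiourea-linked sulfonamide.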